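Amide series: fluoro-to-hydrogen step toward compound 4

The source may report more compounds than this note shows. Statements on the series, on what has been measured and on what is new or still open speak of the compounds shown alone.

Measured so far:
compound 1 `COc1cc2cc(C(=O)NCc3ccc(F)cc3)c(=O)oc2cc1OCCCOc1no[n+]([O-])c1S(=O)(=O)c1ccccc1` — 770 nM
compound 2 `COc1cc2cc(C(=O)Nc3ccccc3)c(=O)oc2cc1OCCCOc1no[n+]([O-])c1S(=O)(=O)c1ccccc1` — 1190 nM
compound 3 `COc1cc2cc(C(=O)NCCCc3ccc(F)cc3)c(=O)oc2cc1OCCCOc1no[n+]([O-])c1S(=O)(=O)c1ccccc1` — 690 nM

The three compounds share one core and differ only in the group on the amide nitrogen. In a functional assay on MDA-MB-231 cells (Homo sapiens) for inhibition, read by MTT assay, with a stated time of 48 h (on this read-out lower numbers stand for stronger inhibition and higher numbers for weaker inhibition), compound 1 gives 770 nM and stands second highest of the three numbers; its gaps to the neighbours are a 1.1-fold lower number from compound 1 to compound 3 (0.05 log units; within the scatter) and a 1.5-fold higher number from compound 1 to compound 2 (0.19 log units; within the scatter), both within the scatter. The remaining pair behaves the same way, a 1.7-fold lower number from compound 2 to compound 3 (0.24 log units; within the scatter). No change at the amide nitrogen seen so far has moved the read-out beyond the scatter.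

Compound 4 `COc1cc2cc(C(=O)NCc3ccccc3)c(=O)oc2cc1OCCCOc1no[n+]([O-])c1S(=O)(=O)c1ccccc1` differs from compound 1 in one place: hydrogen in place of fluoro on an aromatic carbon. Going by the values given here, no measured step isolates this change. The step of a 1.5-fold higher number from compound 1 to compound 2 (0.19 log units; within the scatter) contains it, but together with a change of the linker, and the step of a 1.1-fold lower number from compound 1 to compound 3 (0.05 log units; within the scatter) alters only the chain while keeping the fluoro. Since every recorded step lies within the scatter, no step beyond the scatter is expected for compound 4 in this assay. The expected step is a 1.1-fold higher number from compound 1 to compound 4 (0.04 log units; within the scatter). Compound 4 is therefore estimated at 850 nM, with a range of 450 nM to 1600 nM.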

Compound 4, half-maximal inhibitory concentration: 1060 nM
Beside the measured number, compound 4's estimate is 1.2-fold (0.10 log units) below it; low and high end bracket the measured number.
By their numbers in this assay, from the lowest: compounds 3, 1, 4 and 2 (each within the scatter of the next).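

Going by these compounds alone, compound 4 gives the first clean reading of this change, since only the fluoro of the 4-fluorobenzyl group gives way to hydrogen while the rest of compound 1 stays the same: in this assay the step is a 1.4-fold higher number from compound 1 to compound 4 (0.14 log units; within the scatter). At this place on the aromatic ring, para to a large group, removing the single fluorine therefore produces no change that can be told from the scatter, and the two steps that also alter the amide substituent, a 1.5-fold higher number from compound 3 to compound 4 (0.19 log units; within the scatter) and a 1.1-fold lower number from compound 2 to compound 4 (0.05 log units; within the scatter), likewise stay within it, so all four compounds now lie within the scatter of one another. Nothing available explains the size of the fluoro-to-hydrogen step, and no measurement beyond these read-outs bears on it.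

Among the compounds shown, this ring position carries only fluoro or hydrogen, leaving open whether chloro, methoxy or trifluoromethyl there would give a step beyond the scatter. Going by these compounds, the amide nitrogen likewise carries only phenyl, benzyl, 4-fluorobenzyl and 3-(4-fluorophenyl)propyl, so the response to a substituent bearing an amine or a carboxylic acid remains open.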